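The source may hold more compounds than are shown below. What is called first, only, known or untested is meant among the compounds shown, and "the series" means these compounds.

Four compounds share one core. In an ADME assay on Vero cells (Chlorocebus sabaeus) for cytotoxicity, read by MTT assay (on this read-out lower numbers stand for stronger inhibition and higher numbers for weaker inhibition), compound 1 (`CN(Cc1ccccc1)c1cc(C(=O)Nc2ccccc2)ncn1`) gives 314000 nM as its reading. Compound 2 (`CN(Cc1ccc(Cl)cc1)c1cc(C(=O)Nc2ccccc2)ncn1`), with chloro in place of hydrogen on an aromatic carbon, gives 207000 nM as its reading. These two numbers lie within the usual scatter of each other, so compound 2 stands level with compound 1 and not apart from it. For the measured compounds named here, no result was reported for compound 3 (`CN(Cc1ccc(C#N)cc1)c1cc(C(=O)Nc2ccccc2)ncn1`), which stands as "not determined" (no result reported), and this leaves only two numbers to work from.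

The next compound is compound 4 (`CN(Cc1ccc(Cl)cc1)c1cc(C(=O)Nc2ccncc2)ncn1`). Its difference from compound 2 is this: pyridin-4-yl in place of phenyl on an amide-type nitrogen. Going by the values given here, the only measured step (a 1.5-fold lower number from compound 1 to compound 2 (0.18 log units; within the scatter)) is within the scatter, and it lies on an aromatic carbon, not on the amide-type nitrogen. Among the compounds with values here, no measured step covers the new change, so the data offer no sign of a shift in either direction. The expectation is therefore no step beyond the scatter, and the estimate amounts to a 1.1-fold higher number from compound 2 to compound 4 (0.03 log units; within the scatter) in this case. For compound 4 the estimated value is 220000 nM with an expected range from 90000 nM to 500000 nM for repeated measurements.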

Compound 4, half-maximal inhibitory concentration: 282000 nM
The estimate for compound 4 lay 1.3-fold (0.11 log units) below the measured number; the measured number falls inside the stated range.
By their numbers in this assay, from the lowest: compounds 2, 4 and 1 (each within the scatter of the next).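

Replacing phenyl with pyridin-4-yl on the amide-type nitrogen gives a 1.4-fold higher number from compound 2 to compound 4 (0.13 log units; within the scatter) in this assay, so compound 2 and compound 4 stand level in this assay. For the compounds shown here, this is the first measured change at this amide-type nitrogen, and it shows that a ring nitrogen, with the one hydrogen-bond acceptor that pyridin-4-yl brings and phenyl lacks, can enter here without taking the reading beyond the usual scatter, at least while the chloro group of compound 2 stays in place. Nothing in the information at hand explains this result.

The compounds shown test only this one exchange of an aromatic ring at this place, so it remains open whether a phenyl ring carrying an amine or a carboxylic acid, or a saturated ring such as cyclohexyl, would also stay level with compound 2. From the compounds shown here alone, it is also open whether pyridin-4-yl would give the same result on compound 1, which has no chloro group, because a single step cannot show whether the change behaves alike on a different partner.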